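Adding a Third Methoxy Group: Expected Potency of Compound 4

This account rests on a few compounds, and the source may have more. Where it says the series, first, only, none or still open, it means among the compounds named here.

Measured compounds:
- compound 1, `O=S(=O)(c1ccccc1)c1nc2ccccc2nc1Nc1ccccc1`: 1630 nM
- compound 2, `COc1ccc(Nc2nc3ccccc3nc2S(=O)(=O)c2ccccc2)cc1`: 2420 nM
- compound 3, `COc1cc(Nc2nc3ccccc3nc2S(=O)(=O)c2ccc(C)cc2)cc(OC)c1`: > 50000 nM

In a functional assay on HCT-116 cells (Homo sapiens) for cytotoxicity, read by MTT assay, with a stated time of 72 h (on this read-out lower numbers stand for stronger inhibition and higher numbers for weaker inhibition), compound 1 gives 1630 nM. Compound 2 carries one extra group, (methoxy in place of hydrogen on an aromatic carbon), and in this assay compound 2 gives 2420 nM. The resulting step, a 1.5-fold higher number from compound 1 to compound 2 (0.17 log units; within the scatter), is too small to count as a real change.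

Compound 3 belongs to a different core, and the difference between the two cores is not broken down here. For compound 3 the read-out in this assay is only a limit of the assay, > 50000 nM, not a number (the limit of > 50000 nM in this assay, at which 1 of the 3 values shown sits).

Compound 4, `COc1cc(Nc2nc3ccccc3nc2S(=O)(=O)c2ccc(C)cc2)cc(OC)c1OC`, has not yet been measured. It differs from compound 3 by methoxy in place of hydrogen on an aromatic carbon. Among the compounds with values here, this is the same kind of change as the one from compound 1 to compound 2, but the surroundings differ: in compound 4 the new group sits ortho to two methoxy groups and para to a large group, whereas in compound 2 it sits only para to a large group.

For compound 4 the expected step is a step that the limit leaves unreadable from compound 3 to compound 4, because the earlier step of a 1.5-fold higher number from compound 1 to compound 2 (0.17 log units; within the scatter) stayed within the scatter and compound 3 already sits at the limit of > 50000 nM in this assay, at which 1 of the 3 values shown sits. Compound 4 is therefore expected to remain at or beyond the limit of this assay, with an estimate of 60000 nM and a likely range from 20000 nM to 200000 nM.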

Compound 4, half-maximal inhibitory concentration: 10800 nM
Estimate against measurement, compound 4: 5.6-fold (0.74 log units) above, outside the stated range (below it).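

In this assay, the step for methoxy in place of hydrogen on an aromatic carbon is an at least 4.6-fold lower number from compound 3 to compound 4 (0.66 log units; beyond the scatter), so this change does not have the same outcome on the two cores: the same change on two cores in this assay, a 1.5-fold higher number (0.17 log units; within the scatter) from compound 1 to compound 2 and an at least 4.6-fold lower number (0.66 log units; beyond the scatter) from compound 3 to compound 4, at least 6.8-fold (0.83 log units) apart, beyond the scatter of two such steps. Going by these compounds, compound 3 has only a limit of the assay and not a number, so the true size of its step to compound 4 remains unknown and the printed size is only a minimum: the limit of > 50000 nM in this assay, at which 1 of the 4 values shown sits. Within the data shown here, the result does not show why the outcomes differ or give a rule for the whole series, since there are only two pairs, they differ in core, and the new methoxy in compound 4 sits ortho to two methoxy groups and para to a large group, whereas in compound 2 it sits only para to a large group.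

The compounds shown leave open whether the different outcome follows the core or the neighbouring methoxy groups, a question that a single methoxy on the core of compound 3, or three methoxy groups on the core of compound 1, could help to settle. Also open, on these data alone, is whether an ethoxy group or an amine in the place of the new methoxy would give a similar step.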